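Swapping the amine on the amide: expected cell toxicity

The source may report more compounds than this note shows. Statements on the series, on what has been measured and on what is new or still open speak of the compounds shown alone.

Measured so far:
- compound 1 `CO[C@H]1CC[C@H](NC(=O)c2n[nH]cc2NC(=O)c2c(C)nc3ccccn23)CC1`: 34000 nM
- compound 2 `COc1cccc(OC)c1C(=O)Nc1c[nH]nc1C(=O)NN1CCOCC1`: > 50000 nM
- compound 3 `CO[C@H]1CC[C@H](NC(=O)c2n[nH]cc2NC(=O)c2ccc(N3CCCC3)cc2)CC1`: > 50000 nM

Of the compounds shown here, three have been tested in an ADME assay on MRC5 cells (Homo sapiens) for inhibition, with a stated time of 72 h; on this read-out higher numbers stand for an effect only at larger amounts of compound and lower numbers for an effect already at smaller amounts. Compound 1 gives 34000 nM. For compound 2 the assay reports only the limit > 50000 nM, which is the edge of what the assay can read and not a number. For compound 3 the result is likewise the limit > 50000 nM. Compound 2 therefore stands at the limit of > 50000 nM in this assay, at which 2 of the 3 values shown sit, so its true value is not known, only that it lies past that edge.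

Compound 4 `COc1cccc(OC)c1C(=O)Nc1c[nH]nc1C(=O)NCc1ncccc1C` has not yet been measured. It differs from compound 2 in one place: (3-methylpyridin-2-yl)methyl in place of morpholin-4-yl on an amide-type nitrogen. The change sits on an amide-type nitrogen whose other neighbour is a carbonyl carbon.

Among the compounds with values here, no step between two measured compounds that differ in one place is available, so the size of the change cannot be read from the data. Since compound 2 shows only a limit, the expected step of an at least 1.1-fold lower number from compound 2 to compound 4 (0.04 log units; that floor lies within the scatter) is no more than the usual scatter, in no particular direction. The estimate for compound 4 in this assay is 45000 nM, with a range from 15000 nM to 100000 nM, and it is quite likely that the assay will again report only a limit.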

Compound 4, half-maximal effective concentration: > 50000 nM
Compound 4: a limit, no number; the forecaster's own chance of this, stated with the estimate: 60%; middle value at least 1.1-fold (0.04 log units) away from the limit.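

Compound 2 and compound 4 both end at the edge of what this assay can read, so no step can be read for the swap of morpholin-4-yl for (3-methylpyridin-2-yl)methyl, because both results are limits: the limit of > 50000 nM in this assay, at which 3 of the 4 values shown sit. The compounds shown leave open how far past that limit each true value lies and whether the swap changes it at all.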